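The source may report more compounds than this note shows. Statements on the series, on what has been measured and on what is new or still open speak of the compounds shown alone.

Working notes on the series.

Of the compounds shown here, two have been measured in a functional assay on A673 cells (Homo sapiens) for inhibition, read by sulforhodamine B assay, with a stated time of 48 h; on this read-out lower numbers stand for stronger inhibition of growth and higher numbers for weaker inhibition of growth. Compound 1 `CCCC/C=C\CCCCCCCCCCCc1cc2cc(O)ccc2o1` gives 190 nM in this assay. Compound 2 `CCCC/C=C\CCCCCCCCCCC[C@H](O)Cc1cc(O)ccc1O` gives 320 nM in this assay. Compound 2 thus holds the higher of the two numbers, but the gap to compound 1 lies within the scatter of repeated measurements, so the two values cannot be told apart, and since compound 1 and compound 2 differ in more than one place nothing further is drawn from the pair.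

Compound 3 `CCCC/C=C\CCCCCCCCC[C@H](O)Cc1cc(O)ccc1O` has not yet been measured in this assay. Relative to compound 2 the change is hex-1-en-1-yl in place of oct-3-en-1-yl on a saturated chain carbon, ten or more bonds along the chain from an oxygen on a saturated carbon. The hydroquinone part and the hydroxyl-bearing chain carbon of compound 2 stay untouched; only the length of the lipophilic tail is reduced. Among the measured compounds shown here, no measured step of this kind exists, so there is no anchor for its size. Compound 3 is expected to land close to compound 2, with a step of a 1.3-fold higher number from compound 2 to compound 3 (0.12 log units; within the scatter) that would stay within the scatter or show at most a modest weakening. The value expected for compound 3 in this assay is 420 nM, within a range from 150 nM to 1200 nM.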

Compound 3, concentration for 50% growth inhibition: 160 nM
Compound 3: middle estimate off by 2.6-fold (0.42 log units), on the high side; the range from low to high includes it.
By their numbers in this assay, from the lowest: compounds 3, 1 and 2 (each within the scatter of the next).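

In this assay, among the compounds shown here, hex-1-en-1-yl in place of oct-3-en-1-yl on a saturated chain carbon, ten or more bonds along the chain from an oxygen on a saturated carbon, gives a 2.0-fold lower number from compound 2 to compound 3 (0.30 log units; within the scatter), the only step that can be read so far. The two compounds therefore cannot be told apart, and this position accepts either tail without a change that the assay can resolve, which the earlier pair, differing in more than one place, could not show. No measurement at hand bears on why the number holds across this change.

On these data alone, one step between two tails says nothing about how far this tolerance extends, so it remains open whether a much shorter chain such as butyl, or a longer chain than oct-3-en-1-yl, would keep the number within the scatter. Also open, as far as these compounds go, is whether the double bond is needed at all, which a fully saturated chain would test, and whether a carboxylic acid or an amine at the end of the tail would be accepted at this position.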